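The compounds below may be only part of what the source reports. "The series", "measured", "known", "first", "only" and "open" are said of these compounds alone.

In an ADME assay on L02 cells (Homo sapiens) for cytotoxicity, read by MTT assay, with a stated time of 24 h (a lower number here means a stronger inhibitor, a higher number a weaker inhibitor), compound 1 (`COc1cc(/C=C2\CN(C)C/C(=C\c3cccnc3)C2=O)cc(OC)c1OC`) gives 14400 nM and compound 2 (`CN1C/C(=C\c2ccc(C(F)(F)F)cc2)C(=O)/C(=C/c2cccnc2)C1`) gives 15600 nM, a pair within the scatter of each other. Compound 3 (`CN1C/C(=C\c2ccc(C#N)cc2)C(=O)/C(=C/c2cccnc2)C1`) reads > 20000 nM, which is a limit of the assay and not a number. Among the measured compounds shown here, compound 2 therefore sits level with compound 1, the only other compound here with an exact number.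

Compound 4 (`CN1C/C(=C\c2ccncc2)C(=O)/C(=C/c2ccc(C(F)(F)F)cc2)C1`) departs from compound 2 by pyridin-4-yl in place of pyridin-3-yl on a double-bonded chain carbon bound to a double-bonded ring carbon. For the measured compounds named here, no measured step covers this place. Going by the values given here, the one measured step, an at least 1.2-fold higher number from compound 2 to compound 3 (0.10 log units; that floor lies within the scatter), puts cyano in place of trifluoromethyl on an aromatic carbon, so it bears only indirectly, and its floor lies within the scatter. Among the compounds with values here, with that small step from compound 2 as the only guide, no shift beyond the scatter is expected in this assay, and no direction is favoured.

The expected change is a 1.1-fold lower number from compound 2 to compound 4 (0.05 log units; within the scatter). The estimated value for compound 4 is 14000 nM, with an expected range of 7000 nM to 20000 nM.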

Compound 4, half-maximal inhibitory concentration: 17400 nM
The estimate for compound 4 lay 1.2-fold (0.09 log units) below the measured number; low and high end bracket the measured number.
By their numbers in this assay, from the lowest: compounds 1, 2 and 4 (each within the scatter of the next). At a limit, above all of these: compound 3.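

In this assay, pyridin-4-yl in place of pyridin-3-yl on a double-bonded chain carbon bound to a double-bonded ring carbon gives a 1.1-fold higher number from compound 2 to compound 4 (0.05 log units; within the scatter), so the exchange of one pyridinyl group for the other leaves the reading unchanged within the scatter. Among the compounds shown here, the only earlier step, an at least 1.2-fold higher number from compound 2 to compound 3 (0.10 log units; that floor lies within the scatter), concerned a different place, so this is the first measured step at this position. Compound 4 carries an exact number, while compound 3 remains a limit of the assay and not a number: the limit of > 20000 nM in this assay, at which 1 of the 4 values shown sits.

As far as these compounds go, whether pyridin-2-yl, or a carboxylic acid or an amine on the aromatic ring at this place, would move the reading beyond the scatter remains open. Also open, from the compounds shown here alone, is whether the same pyridinyl exchange would read alike with nitrile in place of trifluoromethyl.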